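The source may hold more compounds than are shown below. What is called first, only, known or untested is meant among the compounds shown, and "the series" means these compounds.

Measured in a functional assay on SMMC-7721 cells (Homo sapiens) for cytotoxicity, read by MTT assay, with a stated time of 72 h; on this read-out higher numbers stand for weaker inhibition and lower numbers for stronger inhibition:
- compound 1 `CC(C)=C1C(=O)N(c2ccc(Cl)cc2)N(c2ccc(Cl)cc2)C1=O`: 45600 nM
- compound 2 `O=C1C(=Cc2ccc(F)cc2)C(=O)N(c2ccc(Cl)cc2)N1c1ccc(Cl)cc1`: 23300 nM
- compound 3 `O=C1C(=Cc2ccc(Cl)cc2)C(=O)N(c2ccc(Cl)cc2)N1c1ccc(Cl)cc1`: 30900 nM

Compound 3, at 30900 nM, lies within the scatter of both compound 2 and compound 1, so no order is claimed for it against either one. Compound 4 `COc1cccc(C=C2C(=O)N(c3ccc(Cl)cc3)N(c3ccc(Cl)cc3)C2=O)c1O` differs from compound 3 by 2-hydroxy-3-methoxyphenyl in place of 4-chlorophenyl on a double-bonded chain carbon bound to a double-bonded ring carbon.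

Among the compounds with values here, the only measured step between close neighbours is a 1.3-fold higher number from compound 2 to compound 3 (0.12 log units; within the scatter), chloro in place of fluoro, and it stays within the scatter. It bears on the same place in the structure but only on a single substituent swap. Within the data shown here, no measured compound carries a hydroxy or methoxy group, so the data offer no direct precedent for this change. Compound 1, at 45600 nM, also differs from compound 3 in this place, and that gap too stays within the scatter. On this evidence, no clear step beyond the scatter is expected in this assay, and the direction remains uncertain. The expected change is a 1.4-fold lower number from compound 3 to compound 4 (0.15 log units; within the scatter). For compound 4 the estimated value is 22000 nM, with an expected range from 7000 nM to 60000 nM.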

Compound 4, half-maximal inhibitory concentration: 64900 nM
The estimate for compound 4 lay 3.0-fold (0.47 log units) below the measured number; measured number outside the range, above it.
By their numbers in this assay, from the lowest: compounds 2, 3, 1 and 4 (each within the scatter of the next, the first and the last beyond it).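

In this assay the place on a double-bonded chain carbon bound to a double-bonded ring carbon now shows a step beyond the scatter: 2-hydroxy-3-methoxyphenyl in place of 4-chlorophenyl gives a 2.1-fold higher number from compound 3 to compound 4 (0.32 log units; beyond the scatter) and in place of 4-fluorophenyl gives a 2.8-fold higher number from compound 2 to compound 4 (0.44 log units; beyond the scatter) on the same shared core. Within the data shown here, the earlier chloro for fluoro swap at this place stayed within the scatter, so this is the first sign that the substituent here can move the number, and both steps point towards weaker inhibition, though only modestly. No measured evidence on the cause of this shift is available.

The hydroxy and methoxy groups enter together, so the compounds shown leave open how the step divides between them, and whether either group alone would give a step beyond the scatter. Also open, on these data alone, is how a phenyl ring carrying an amine or a carboxylic acid at this place would read in this assay and whether any group here could bring the numbers lower than those seen so far.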